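The source may hold more compounds than are shown below. What is called first, only, known or untested is meant among the compounds shown, and "the series" means these compounds.

In a functional assay on HBL-100 cells (Homo sapiens) for inhibition, read by sulforhodamine B assay, with a stated time of 48 h (a lower number here means a stronger inhibitor of growth, a higher number a weaker inhibitor of growth), compound 1 `O=C(CCC(F)(F)C(F)(F)C(F)(F)C(F)(F)F)NCCCCCCCCCN[C@@H]1[C@H](O)[C@@H](O)[C@H](O)[C@H]2COC(=O)N21` reads > 100000 nM, which is a limit of the assay and not a number. Going by the values given here, compound 2 `O=C(CCC(F)(F)C(F)(F)C(F)(F)C(F)(F)C(F)(F)C(F)(F)F)NCCCCCCCCCN[C@@H]1[C@H](O)[C@@H](O)[C@H](O)[C@H]2COC(=O)N21` gives 16000 nM, the only actual number so far. Compound 3 `O=C(CCC(F)(F)C(F)(F)C(F)(F)C(F)(F)C(F)(F)C(F)(F)C(F)(F)C(F)(F)F)NCCCCCCCCCN[C@@H]1[C@H](O)[C@@H](O)[C@H](O)[C@H]2COC(=O)N21` repeats the same kind of change on the fluorinated chain: 1,1,2,2,2-pentafluoroethyl in place of fluoro on a saturated chain carbon bound to two fluorine atoms and a saturated chain carbon. Among the compounds with values here, one measured step bears on this, an at least 6.2-fold lower number from compound 1 to compound 2 (0.79 log units; beyond the scatter). Going by these compounds, that step starts from a limit, so its full size is unknown. A further, modest fall in the number is expected in this assay, with an expected step of a 2.7-fold lower number from compound 2 to compound 3 (0.43 log units; beyond the scatter). For compound 3 the estimated value is 6000 nM, with an expected range of 1800 nM to 20000 nM.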

Compound 3, concentration for 50% growth inhibition: > 100000 nM
Compound 3: a limit, no number; the forecaster's own chance of this, stated with the estimate: 8%; middle value at least 16-fold (1.22 log units) away from the limit.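

In this assay, the change that lowered the number one step earlier raises it here, with an at least 6.2-fold higher number from compound 2 to compound 3 (0.79 log units; beyond the scatter), so its direction on this saturated chain carbon depends on the fluorinated chain it extends. Going by these compounds, compound 3 gives > 100000 nM, a limit and not a number, so the full size of this rise is unknown. Compound 2 alone gives a number among the three, and the others sit at a limit: the limit of > 100000 nM in this assay, at which 2 of the 3 values shown sit.

On these data alone, whether growth inhibition depends on fluorine or on chain length alone stays open. An unfluorinated octyl chain in place of the fluorinated chain would test this in this assay.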